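This account rests on a few compounds, and the source may have more. Where it says the series, first, only, none or still open, it means among the compounds named here.

Of the compounds shown here, three of one shared core have been measured in a functional assay on CCRF-CEM cells (Homo sapiens) for antiproliferative activity (on this read-out lower numbers stand for stronger inhibition and higher numbers for weaker inhibition), and they differ only in the aromatic group attached to an aromatic carbon of the core. Compound 2 `COc1cc(C(=O)c2sc(-c3cccs3)cc2N)cc(OC)c1OC` gives 9.4 nM, the lowest of the three numbers. Compound 1 `COc1cc(C(=O)c2sc(-c3ccc(C)cc3)cc2N)cc(OC)c1OC` gives 15 nM, and the step of a 1.6-fold lower number from compound 1 to compound 2 (0.20 log units; within the scatter) lies within the scatter, so the two cannot be told apart. Compound 3 `COc1cc(C(=O)c2sc(-c3ccc(Cl)cc3)cc2N)cc(OC)c1OC` gives 70 nM, and the step of a 7.4-fold higher number from compound 2 to compound 3 (0.87 log units; beyond the scatter) is a clear weakening.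

Compound 4 `COc1cc(C(=O)c2sc(-c3ccc(F)cc3)cc2N)cc(OC)c1OC` has not yet been measured in this assay. It differs from compound 2 in one place: 4-fluorophenyl in place of thiophen-2-yl on an aromatic carbon. The group that enters is a six-membered ring of carbon only with one substituent, like the groups in compound 1 and compound 3, so both measured swaps away from thiophen-2-yl bear on it. One of those swaps, a 1.6-fold lower number from compound 1 to compound 2 (0.20 log units; within the scatter), was within the scatter; the other, a 7.4-fold higher number from compound 2 to compound 3 (0.87 log units; beyond the scatter), was a modest rise. A rise of a size between these two is therefore expected for compound 4, estimated as a 3.2-fold higher number from compound 2 to compound 4 (0.50 log units; beyond the scatter). In this assay compound 4 is expected to give about 30 nM, with a likely range from 10 nM to 90 nM.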

Compound 4, half-maximal inhibitory concentration: 15 nM
Compound 4: the middle estimate sits 2.0-fold (0.30 log units) above what was measured; measured number inside the range.
By their numbers in this assay, from the lowest: compounds 2, 1 and 4 (each within the scatter of the next); then compound 3.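

In this assay the 4-fluorophenyl group of compound 4 and the thiophen-2-yl group of compound 2 cannot be told apart (a 1.6-fold higher number from compound 2 to compound 4 (0.20 log units; within the scatter)), so this carbon next to the ring sulfur accepts a second six-membered ring of carbon only without a loss beyond the scatter. The fluoro and methyl groups also cannot be told apart on that ring (no change at the digits printed from compound 1 to compound 4 (within the scatter)), whereas exchanging chloro for fluoro gives a modest but clear change (a 4.7-fold lower number from compound 3 to compound 4 (0.67 log units; beyond the scatter)). Among the three compounds with a substituted six-membered ring, compound 3 alone stands apart, which shows that the weaker result belongs to the chloro group in particular and not to the six-membered ring as such.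

Nothing available explains why chloro behaves differently from fluoro and methyl here. Going by these compounds, it remains open whether a bromo, methoxy or amino group in the same place on the ring would track compound 3 or stay with compound 1 and compound 4, and whether an unsubstituted phenyl ring would do the same.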